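Cytotoxicity notes: acetylthiophene arm replacing the dimethylaminophenyl arm

The source may report more compounds than this note shows. Statements on the series, on what has been measured and on what is new or still open speak of the compounds shown alone.

Compound 3 `CCOC(=O)CCCCCOc1cccc(CN(C(=O)c2ccc(-c3cccc(N(C)C)c3)cc2)C(C)C)c1` is the ethyl ester of the series and carries the 3-(dimethylamino)phenyl arm. In an ADME assay on HepG2 cells (Homo sapiens) for cytotoxicity, read by CellTiter-Glo and resazurin assay, with a stated time of 72 h (on this read-out higher numbers stand for an effect only at larger amounts of compound and lower numbers for an effect already at smaller amounts), compound 3 gives only a limit, > 26000 nM. The two measured neighbours stand at the same place. Compound 1 `CC(C)N(Cc1cccc(OCCCCCC(=O)O)c1)C(=O)c1ccc(-c2cccc(N(C)C)c2)cc1`, the free acid, gives a limit of > 26000 nM in this assay. Compound 2 `Cc1nnc(-c2cccc(-c3ccc(C(=O)N(Cc4cccc(OCCCCCC(=O)O)c4)C(C)C)cc3)c2)o1`, with 5-methyl-1,3,4-oxadiazol-2-yl in place of dimethylamino on an aromatic carbon, gives a limit of > 26000 nM as well. The two shown steps, a step that the two limits leave unreadable from compound 1 to compound 2 and a step that the two limits leave unreadable from compound 1 to compound 3, have no readable size because every value shown shares one limit (the limit of > 26000 nM in this assay, at which 3 of the 3 values shown sit).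

Compound 4 `CCOC(=O)CCCCCOc1cccc(CN(C(=O)c2ccc(-c3ccc(C(C)=O)s3)cc2)C(C)C)c1` differs from compound 3 in one place: 5-acetylthiophen-2-yl in place of 3-(dimethylamino)phenyl on an aromatic carbon. For the measured compounds named here, no measured step touches this arm, so none bears on it beyond the observation that all three changes made so far have left the read-out at its limit. The step from compound 3 is expected to be a step that the limit leaves unreadable from compound 3 to compound 4, most likely again unreadable. Compound 4 is estimated at 30000 nM, with a range from 12000 nM to 100000 nM.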

Compound 4, half-maximal effective concentration: > 26000 nM
Compound 4 ended at the assay's limit; the forecaster's own chance of this, stated with the estimate: 80%; the middle value lies beyond the limit too.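

No step can be read between compound 3 and compound 4, because both sit at the same limit: the limit of > 26000 nM in this assay, at which 4 of the 4 values shown sit.

The compounds shown leave open whether 5-acetylthiophen-2-yl and 3-(dimethylamino)phenyl differ at all in this assay, and at what concentration, if any, these compounds reach a half-maximal effect.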